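This account rests on a few compounds, and the source may have more. Where it says the series, first, only, none or still open, it means among the compounds named here.

Of the compounds shown here, two carry the shared core and have been measured in a functional assay on KARPAS-299 cells (Homo sapiens) for inhibition, read by CellTiter-Glo, with a stated time of 96 h; a higher number here means a weaker inhibitor, a lower number a stronger inhibitor. Compound 1 `Cc1cc(Nc2ncc(Cl)c(Nc3cn(C)nc3S(=O)(=O)C(C)C)n2)c(OC2CC2)cc1C1COC1` gives 19 nM in this assay. Compound 2 `Cc1cc(Nc2ncc(Cl)c(Nc3cn(C)nc3S(=O)(=O)C(C)C)n2)c(OC(C)C)cc1C1CCNC1` gives 28 nM in this assay, and this number and that of compound 1 sit within the usual scatter of each other, so the two cannot be told apart on these data alone. Going by the values given here, no single-point step between measured compounds is available, so nothing is yet known about how a change at the aromatic carbon bearing the saturated ring moves the number.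

Compound 3 `Cc1cc(Nc2ncc(Cl)c(Nc3cn(C)nc3S(=O)(=O)C(C)C)n2)c(OC(C)C)cc1C1CNC1` differs from compound 2 in one place: azetidin-3-yl in place of pyrrolidin-3-yl on an aromatic carbon. Both groups bring one hydrogen-bond donor and one hydrogen-bond acceptor, and the place on the ring is unchanged. Among the compounds with values here, with no measured step to lean on, the expected step is a small one, either way, and most likely not beyond the scatter. Compound 3 is therefore estimated at 35 nM in this assay, within a range of 15 nM to 80 nM, which means an expected step of a 1.3-fold higher number from compound 2 to compound 3 (0.10 log units; within the scatter).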

Compound 3, half-maximal inhibitory concentration: 60 nM
The estimate for compound 3 lay 1.7-fold (0.23 log units) below the measured number; the measured number falls inside the stated range.
By their numbers in this assay, from the lowest: compounds 1 and 2 (each within the scatter of the next); then compound 3.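

In this assay, going by these compounds alone, the exchange of pyrrolidin-3-yl for azetidin-3-yl gives the first measured step at this aromatic carbon, ortho to a methyl group and para to a large group: a 2.1-fold higher number from compound 2 to compound 3 (0.33 log units; beyond the scatter) is a modest change, but it lies beyond the scatter, which the comparison of compounds 1 and 2 could not show. The number at this place therefore responds to going from the five-membered to the four-membered non-aromatic ring, even though the two groups have the same counts of hydrogen-bond donors and acceptors and the rest of the structure stays the same. Nothing available on these compounds bears on what lies behind this step.

Going by these compounds, how piperidin-4-yl, or a methyl group on the ring nitrogen of azetidin-3-yl, would move the number at this carbon remains open, and a single step between two ring sizes does not establish a trend with ring size. Compound 1 differs from compound 3 in more than one place, so it cannot settle either question.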